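A few compounds are considered here, and "the series" means these few. Any claim that something is new, unique, unknown or untested is made for them only; others in the source may bear on it.

Measured so far in a functional assay on Daudi cells (Homo sapiens) for cytotoxicity, read by trypan blue exclusion, with a stated time of 96 h; on this read-out lower numbers stand for stronger inhibition of growth and higher numbers for weaker inhibition of growth:
compound 1 `COc1ccc(NS(=O)(=O)/C=C/c2c(OC)cc(OC)cc2OC)cc1`: 100 nM
compound 2 `COc1cc(OC)c(/C=C/S(=O)(=O)Nc2ccc(OC)c(O)c2)c(OC)c1`: 25 nM

Of these two compounds, compound 2 has the lower number, at 25 nM in this assay and therefore shows the stronger inhibition of growth. Compound 3 `COc1cc(OC)c(/C=C/S(=O)(=O)Nc2ccc(OC)c(N)c2)c(OC)c1` has not yet been measured. It differs from compound 2 by amino in place of hydroxy on an aromatic carbon ortho to a methoxy group and meta to a large group. The same change can be read as 3-hydroxy-4-methoxyphenyl to 3-amino-4-methoxyphenyl.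

Within the data shown here, only one measured step bears on this change. Hydroxy in place of hydrogen on an aromatic carbon gave a 4.0-fold lower number from compound 1 to compound 2 (0.60 log units; beyond the scatter) and that step is modest. Among the measured compounds shown here, no measured compound carries the amino group, so the data offer no direct comparison between amino and hydroxy. A small step is therefore expected, most likely none beyond the scatter, and the number should stay close to that of compound 2. The expected step is a 1.3-fold lower number from compound 2 to compound 3 (0.10 log units; within the scatter) and it remains an estimate. In this assay compound 3 is estimated at 20 nM and expected to fall from 6 nM to 70 nM on repeated measurement.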

Compound 3, concentration for 50% growth inhibition: 8 nM
The estimate for compound 3 lay 2.5-fold (0.40 log units) above the measured number, and the stated range covers the measured number.
By their numbers in this assay, from the lowest: compound 3; then compound 2; then compound 1.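

In this assay, replacing hydroxy with amino on the aromatic carbon ortho to a methoxy group gives a 3.1-fold lower number from compound 2 to compound 3 (0.49 log units; beyond the scatter), a step beyond the scatter. Among these compounds, the earlier pair showed only that a hydroxy group at this position gives a lower number than hydrogen; this result shows that the identity of the added group also matters, even though hydroxy and amino have the same tally of heavy atoms, hydrogen-bond donors and acceptors. Measured against hydrogen, amino gives a 13-fold lower number from compound 1 to compound 3 (1.10 log units; beyond the scatter), a large step where hydroxy gave a modest one, but nothing available explains why the two groups differ.

The compounds shown leave open whether the lower number depends on the free amino group, since a methylamino, dimethylamino or acetamido group at the same position would be needed to test this. They also do not show how a fluorine, a methyl group or an aminomethyl group would compare there, so the result describes only hydrogen, hydroxy and amino on this core.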